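The source may report more compounds than this note shows. Statements on the series, on what has been measured and on what is new or still open speak of the compounds shown alone.

Compound 3 `CC(C)C(=O)Nc1ncc(SCc2ncc(C(C)(C)C)o2)s1` gives 50 nM in a functional assay on A2780 cells (Homo sapiens) for cytotoxicity (on this read-out higher numbers stand for weaker inhibition and lower numbers for stronger inhibition), and stands level with compound 1 `CC(=O)Nc1ncc(SCc2ncc(C(C)(C)C)o2)s1`, which gives 50 nM; together they hold the lowest numbers of the three, while compound 2 `CC(=O)Nc1ncc(SCc2ncc(CC3CCCCC3)o2)s1` gives 1540 nM. Compound 4 `CC(C)(C)C(=O)Nc1ncc(SCc2ncc(C(C)(C)C)o2)s1` differs from compound 3 by methyl in place of hydrogen on a saturated chain carbon bound to a carbonyl carbon and two saturated chain carbons. The step that bears on this is no change at the digits printed from compound 1 to compound 3 (within the scatter), where isopropyl in place of methyl on a carbonyl carbon left the number unchanged. The large step of a 31-fold higher number from compound 1 to compound 2 (1.49 log units; beyond the scatter) concerns a different place, cyclohexylmethyl in place of tert-butyl on an aromatic carbon, and so says little here. A step of a 1.1-fold higher number from compound 3 to compound 4 (0.04 log units; within the scatter) is therefore expected, meaning none beyond the scatter. Compound 4 is estimated at 55 nM, with a range from 25 nM to 130 nM.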

Compound 4, half-maximal inhibitory concentration: 250 nM
For compound 4 the middle estimate is 4.5-fold (0.66 log units) below the measured one; measured number above the stated range.
By their numbers in this assay, from the lowest: compounds 1 and 3 (each within the scatter of the next); then compound 4; then compound 2.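

In this assay, changing isopropyl to tert-butyl on the carbonyl carbon gives a 5.0-fold higher number from compound 3 to compound 4 (0.70 log units; beyond the scatter), and changing methyl to tert-butyl there gives a 5.0-fold higher number from compound 1 to compound 4 (0.70 log units; beyond the scatter). This place therefore does not accept every group equally: compound 1 and compound 3 read alike, yet one added methyl weakens inhibition. No measurement shown here explains this loss. On these data alone, it remains open whether only the branching of tert-butyl matters, or whether a longer chain such as n-butyl, or a cyclopropyl ring, on the carbonyl carbon would keep the number of compound 3.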